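Phenyl in Place of 3,5-Dimethyl-1,2-oxazol-4-yl on a Shared Core

The source may hold more compounds than are shown below. What is called first, only, known or untested is meant among the compounds shown, and "the series" means these compounds.

Among the measured compounds shown here, the three compounds measured so far share one core. Compound 1 `Cc1ccsc1C(c1c(C)noc1C)N1CCN(c2ncnc3c2cnn3-c2ccccc2)CC1` carries 3,5-dimethyl-1,2-oxazol-4-yl on a saturated chain carbon bound to an amine nitrogen in a ring and an aromatic carbon. In a functional assay on cells (Rhabdomyosarcoma cell, Homo sapiens) for cytotoxicity (a lower number here means a stronger inhibitor, a higher number a weaker inhibitor), compound 1 gives > 25000 nM, which is a limit of the assay rather than a number. Compound 2 `c1ccc(C(c2ccncc2)N2CCN(c3ncnc4c3cnn4-c3ccccc3)CC2)cc1` gives > 25000 nM, again only a limit. Compound 3 `c1ccc(C(c2cccnc2)N2CCN(c3ncnc4c3cnn4-c3ccccc3)CC2)cc1` gives > 25000 nM, also a limit. The step that the two limits leave unreadable from compound 2 to compound 3 cannot be read, since both ends sit at the limit. Across the set, (the limit of > 25000 nM in this assay, at which 3 of the 3 values shown sit), so compound 1 stands with the others at the limit and no order among them can be given.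

Compound 4 `Cc1ccsc1C(c1ccccc1)N1CCN(c2ncnc3c2cnn3-c2ccccc2)CC1` differs from compound 1 in one place: phenyl in place of 3,5-dimethyl-1,2-oxazol-4-yl on a saturated chain carbon bound to an amine nitrogen in a ring and an aromatic carbon. For the measured compounds named here, no measured step bears directly on this exchange; the one step available, from a pyridin-4-yl to a pyridin-3-yl, was itself unreadable. With every value at the limit there is no foothold for a change in either direction, and the step that the limit leaves unreadable from compound 1 to compound 4 is expected to stay within the scatter, most likely with the assay reporting only a limit again. Compound 4 is therefore estimated at 30000 nM, with a range from 8000 nM to 100000 nM.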

Compound 4, half-maximal inhibitory concentration: > 25000 nM
Compound 4: a limit, no number (the forecaster's own chance of this, stated with the estimate: 85%); the middle value does not contradict the limit.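

In this assay compound 4 gives > 25000 nM, which is a limit of the assay and not a number. Its steps from compound 1, compound 2 and compound 3 therefore cannot be read: the limit of > 25000 nM in this assay, at which 4 of the 4 values shown sit. The compounds shown leave open whether any exchange on the saturated chain carbon shifts the result in this assay at all.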